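Two thymidine analogues and a larger ether on the sugar

A few compounds are considered here, and "the series" means these few. Any claim that something is new, unique, unknown or untested is made for them only; others in the source may bear on it.

Measured so far:
- compound 1, `Cc1cn([C@H]2C[C@H](O)[C@@H](CO)O2)c(=O)n(Cc2ccccc2)c1=O`, giving 320000 nM in an assay on isolated protein for inhibition of thymidine kinase, cytosolic (Rattus norvegicus); on this read-out lower numbers stand for stronger inhibition and higher numbers for weaker inhibition
- compound 2, `CCO[C@H]1C[C@H](n2cc(C)c(=O)[nH]c2=O)O[C@@H]1CO`, giving 36000 nM in this assay

Of the two numbers at hand, compound 2 has the lower one, and its gap to compound 1 lies beyond the scatter, so compound 2 is the stronger inhibitor of the pair as far as these two values show. Compound 3, `Cc1cn([C@H]2C[C@H](OCc3ccccc3)[C@@H](CO)O2)c(=O)[nH]c1=O`, has not yet been measured. It differs from compound 2 in one place: phenyl in place of methyl on a saturated chain carbon bound to an oxygen on a saturated carbon. In other words, the ethoxy group on the sugar of compound 2 becomes a benzyloxy group in compound 3, while the rest of the molecule stays the same.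

Going by the values given here, no measured pair here shows what such a change does on this target, so the expectation rests on compound 2 alone. With nothing to point in either direction, the step of a 1.7-fold higher number from compound 2 to compound 3 (0.22 log units; within the scatter) is expected to be small, at most a modest weakening, probably not beyond the scatter. For compound 3 the expected value in this assay is 60000 nM, within a range from 15000 nM to 250000 nM.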

Compound 3, inhibition constant: 12000 nM
Estimate against measurement, compound 3: 5.0-fold (0.70 log units) above, and the stated range ends above it.
By their numbers in this assay, from the lowest: compound 3; then compound 2; then compound 1.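

In this assay, swapping the end methyl of the ethoxy group for phenyl, which turns ethoxy into benzyloxy, gives a 3.0-fold lower number from compound 2 to compound 3 (0.48 log units; beyond the scatter), so this position takes the larger group with a gain in inhibition rather than a loss. Going by these compounds alone, until this result no measured pair showed what any change at this place does; this first step shows that the read-out responds to what sits on the ether oxygen, and that an added six-membered aromatic ring of carbon only is tolerated here, with compound 3 at 12000 nM as the lowest number so far. Nothing measured here gives a reason for this gain.

As far as these compounds go, it remains open whether the gain needs the phenyl ring itself or whether a longer chain, such as a butyl group on the same oxygen, would give a similar number. From the compounds shown here alone, it is also open how a pyridine ring in place of phenyl, or a phenyl ring carrying an amine or a carboxylic acid, would read in this assay, and so whether the number can fall further from this position.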